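Methyl substitution on the shared core: series notes

A few compounds are considered here, and "the series" means these few. Any claim that something is new, unique, unknown or untested is made for them only; others in the source may bear on it.

Measured so far in a functional assay on MDA-MB-231 cells (Homo sapiens) for antiproliferative activity, read by MTT assay, with a stated time of 48 h; on this read-out higher numbers stand for weaker inhibition and lower numbers for stronger inhibition:
- compound 2 `COc1ccc2nc(Nc3ccnc(Nc4ccc(S(N)(=O)=O)cc4)n3)sc2c1` gives 6240 nM
- compound 3 `NS(=O)(=O)c1ccc(Nc2nccc(Nc3nc4ccc(F)cc4s3)n2)cc1` gives 1800 nM
- compound 1 `COc1ccc2nc(Nc3nc(Nc4ccc(S(N)(=O)=O)cc4)ncc3C)sc2c1` gives > 50000 nM, which is a limit of the assay and not a number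

The two cores differ by fluoro in place of methoxy on an aromatic carbon, and this change gave a 3.5-fold lower number from compound 2 to compound 3 (0.54 log units; beyond the scatter). The change methyl in place of hydrogen on an aromatic carbon gave an at least 8.0-fold higher number from compound 2 to compound 1 (0.90 log units; beyond the scatter), the step resting on (the limit of > 50000 nM in this assay, at which 1 of the 3 values shown sits), so its true size is not fixed.

Compound 4 `Cc1cnc(Nc2ccc(S(N)(=O)=O)cc2)nc1Nc1nc2ccc(F)cc2s1` is not yet measured. It differs from compound 3 by methyl in place of hydrogen on an aromatic carbon; the place described is word for word the same as for the change from compound 2 to compound 1, so this is the same change on the other core. Beside the measured step from compound 2 to compound 1, the step of an 11-fold higher number from compound 3 to compound 4 (1.05 log units; beyond the scatter) is expected for compound 4, an expectation that rests on an at least 8.0-fold higher number from compound 2 to compound 1 (0.90 log units; beyond the scatter). Compound 4 is therefore estimated at 20000 nM, with a range from 7000 nM to 60000 nM.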

Compound 4, half-maximal inhibitory concentration: 7580 nM
Beside the measured number, compound 4's estimate is 2.6-fold (0.42 log units) above it, within the range that was stated.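

In this assay, methyl in place of hydrogen on an aromatic carbon gave a 4.2-fold higher number from compound 3 to compound 4 (0.62 log units; beyond the scatter), the same direction as on the other core: the same change on two cores in this assay, an at least 8.0-fold higher number (0.90 log units; beyond the scatter) from compound 2 to compound 1 and a 4.2-fold higher number (0.62 log units; beyond the scatter) from compound 3 to compound 4; the limit leaves it open whether they differ

Fluoro in place of methoxy on an aromatic carbon, read with the methyl group present, gave an at least 6.5-fold lower number from compound 1 to compound 4 (0.81 log units; beyond the scatter), again the same direction as on the other core: the same change on two cores in this assay, a 3.5-fold lower number (0.54 log units; beyond the scatter) from compound 2 to compound 3 and an at least 6.5-fold lower number (0.81 log units; beyond the scatter) from compound 1 to compound 4; the limit leaves it open whether they differ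

Compound 1 gives > 50000 nM, which is a limit of the assay and not a number, so the direction of each change carries from one core to the other, while whether the size carries too is not shown: the limit of > 50000 nM in this assay, at which 1 of the 4 values shown sits.

The compounds shown cover methyl as the only group entering at this place, and only fluoro and methoxy as the groups exchanged, so two pairs in one assay give no rule beyond compound 1, compound 2, compound 3 and compound 4. Going by these compounds, whether ethyl, an amine or a carboxylic acid at the same place would follow the direction seen with methyl remains open.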